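Azetidinylmethoxy pyridines: bromo to methyl steps

The source may hold more compounds than are shown below. What is called first, only, known or untested is meant among the compounds shown, and "the series" means these compounds.

Measured compounds:
compound 1 `Brc1cncc(OC[C@@H]2CCN2)c1`, 0.18 nM
compound 2 `Cc1cncc(OC[C@@H]2CCN2)c1`, 0.047 nM
compound 3 `Brc1ccc(OC[C@H]2CCN2)cn1`, 0.17 nM

In an assay on brain for binding affinity to Neuronal acetylcholine receptor; alpha4/beta2 (Rattus norvegicus), read by radioligand binding (a higher number here means a weaker inhibitor, a lower number a stronger inhibitor), compound 1 gives 0.18 nM. Compound 2 gives 0.047 nM in this assay. The change between them is methyl in place of bromo on an aromatic carbon, and it gives a 3.8-fold lower number from compound 1 to compound 2 (0.58 log units; beyond the scatter). Compound 3 gives 0.17 nM in this assay. Compound 3 and compound 1 share the same atoms joined differently; the difference between the two cores is not broken down here, and their two values lie within the scatter of each other.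

Compound 4 `Cc1ccc(OC[C@H]2CCN2)cn1` is not yet measured. Relative to compound 3 the change is methyl in place of bromo on an aromatic carbon. This is the same kind of change as from compound 1 to compound 2, though the place differs: here it is next to the ring nitrogen and para to a group of 6 heavy atoms, whereas in compound 1 to compound 2 it is two atoms from the ring nitrogen and meta to a group of 6 heavy atoms. Because the first step gave a 3.8-fold lower number from compound 1 to compound 2 (0.58 log units; beyond the scatter), a step of similar size is expected here, a 3.4-fold lower number from compound 3 to compound 4 (0.53 log units; beyond the scatter), with wider uncertainty since the place is not the same. Compound 4 is thus estimated at 0.05 nM in this assay, between 0.02 nM and 0.14 nM.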

Compound 4, inhibition constant: 0.053 nM
The estimate for compound 4 lay 1.1-fold (0.03 log units) below the measured number, and the stated range covers the measured number.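

In this assay, methyl in place of bromo on an aromatic carbon again lowers the number, with a 3.2-fold lower number from compound 3 to compound 4 (0.51 log units; beyond the scatter). Set beside the earlier step, the size of the change carries over between the two cores, and no difference between the steps can be told apart: the same change on two cores in this assay, a 3.8-fold lower number (0.58 log units; beyond the scatter) from compound 1 to compound 2 and a 3.2-fold lower number (0.51 log units; beyond the scatter) from compound 3 to compound 4, 1.2-fold (0.08 log units) apart, within the scatter of two such steps This agreement rests on only two matched pairs in a single assay, so it supports transfer between these two cores but sets no rule for other cores and gives no explanation for the step.

The compounds shown leave open whether a longer chain such as ethyl, or a group such as an amine or a nitrile, would follow the same course in place of bromo on either core. Also open, going by these compounds, is whether the matching steps seen in this assay would appear in any other measurement.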